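A few compounds are considered here, and "the series" means these few. Any claim that something is new, unique, unknown or untested is made for them only; others in the source may bear on it.

Compound 1 `Cc1cc(NC(=O)Nc2cccc(Cl)c2)c2ccccc2n1`: 18000 nM
Compound 2 `CC(=O)c1ccc(NC(=O)Nc2cc(C)nc3ccccc23)cc1`: > 25000 nM
Compound 3 `Cc1cc(NC(=O)Nc2ccc(Cl)cc2)c2ccccc2n1`: > 25000 nM

All three share a core and were tested in an ADME assay on Raji cells (Homo sapiens) for cytotoxicity, with a stated time of 72 h; on this read-out lower numbers stand for an effect already at smaller amounts and higher numbers for an effect only at larger amounts of compound. Among the measured compounds shown here, compound 1 is the only one with a number. The value of compound 2 is a limit of the assay and not a number. As far as these compounds go, the value of compound 3 is likewise a limit of the assay, so compound 3 stands at the limit of > 25000 nM in this assay, at which 2 of the 3 values shown sit, and its true position is unknown beyond that.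

Compound 4 `Cc1cc(NC(=O)Nc2ccc(Cl)c(Cl)c2)c2ccccc2n1` has not been measured yet. It differs from compound 3 by chloro in place of hydrogen on an aromatic carbon, so it carries both chloro groups that compound 1 and compound 3 have one each. For the measured compounds named here, two measured steps bear on this: an at least 1.3-fold higher number from compound 1 to compound 3 (0.14 log units; that floor lies within the scatter), and a step that the two limits leave unreadable from compound 2 to compound 3. Neither gives a readable size. Since compound 1 gives a number while compound 3 only a limit, a small step down is expected, an at least 1.2-fold lower number from compound 3 to compound 4 (0.09 log units; that floor lies within the scatter), though it may stay within the scatter. Compound 4 is therefore estimated at 20000 nM, with a range of 6000 nM to 60000 nM.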

Compound 4, half-maximal effective concentration: 10000 nM
Compound 4: the middle estimate sits 2.0-fold (0.30 log units) above what was measured, within the range that was stated.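

Going from one chloro to two on the same aromatic ring gives the first step in this assay that lies beyond the scatter: an at least 2.5-fold lower number from compound 3 to compound 4 (0.39 log units; beyond the scatter). The same kind of change starting from the other single-chloro compound stays small, with a 1.8-fold lower number from compound 1 to compound 4 (0.26 log units; within the scatter), so the two compounds of that step cannot be put in order, and the gain from a second chloro depends on which chloro is already there. The value of compound 3 is a limit of the assay and not a number, and only a floor can be given for its step because of that limit: the limit of > 25000 nM in this assay, at which 2 of the 4 values shown sit.

As far as these compounds go, the true size of that step stays open. From the compounds shown here alone, it is also open whether an amine or a methoxy group at this place on the ring would lower the number as chloro does.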